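Mirror image of an inactive chloro compound

A few compounds are considered here, and "the series" means these few. Any claim that something is new, unique, unknown or untested is made for them only; others in the source may bear on it.

In a functional assay on SW480 cells (Homo sapiens) for cytotoxicity, read by MTT assay, with a stated time of 48 h (a higher number here means a weaker inhibitor, a lower number a stronger inhibitor), the measured compounds stand as follows:
- compound 1 `CCOC(=O)[C@]1(C(=O)Nc2ccccc2)C[C@@H]1c1cc(OC)c(OC)c(OC)c1` gives 31700 nM as its value
- compound 2 `CCOC(=O)C1(C(=O)Nc2ccccc2Cl)CC1c1cc(OC)c(OC)c(OC)c1` gives 27200 nM; 66700 nM (2 entries) as its values
- compound 3 `CCOC(=O)[C@]1(C(=O)Nc2ccccc2Cl)C[C@@H]1c1cc(OC)c(OC)c(OC)c1` gives > 100000 nM as a limit, not a number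

Compound 3 thus stands at > 100000 nM in this assay as a limit only. Compound 4 `CCOC(=O)[C@@]1(C(=O)Nc2ccccc2Cl)C[C@H]1c1cc(OC)c(OC)c(OC)c1` is its mirror image (the two compounds have the same atoms and bonds and differ only in configuration as drawn: 2 of 2 stereo elements differ (all stereocentres are inverted: mirror images); a stereocentre at a saturated ring carbon is drawn R in compound 3 and S in compound 4; a stereocentre at a saturated ring carbon is drawn R in compound 3 and S in compound 4), with the same atoms and bonds. Among the compounds with values here, the one measured step is an at least 3.1-fold higher number from compound 1 to compound 3 (0.49 log units; beyond the scatter) for chloro in place of hydrogen, a different kind of change, so it sets no size here. Compound 2 is more telling (the fact that one of compounds 2 and 3 is drawn with a defined configuration and the other without, at the place where they differ). If compound 2 is a mixture of both mirror images, its entries (the several entries of compound 2 in this assay, 27200 nM; 66700 nM (2 entries)) suggest that compound 4 may be the stronger partner. The expected change is an at least 4.0-fold lower number from compound 3 to compound 4 (0.60 log units; beyond the scatter) toward a lower number. For compound 4 the estimated value is 25000 nM with an expected range of 10000 nM to 80000 nM in this estimate.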

Compound 4, half-maximal inhibitory concentration: 30100 nM
Compound 4: the middle estimate sits 1.2-fold (0.08 log units) below what was measured; low and high end bracket the measured number.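

In this assay, the change of configuration alone gives an at least 3.3-fold lower number from compound 3 to compound 4 (0.52 log units; beyond the scatter), whereas the earlier step changed a substituent. Activity in this series therefore depends on the configuration at these two ring carbons, even with the same atoms and bonds: the fact that compounds 3 and 4 differ only in the configuration as drawn Compound 3 gives only a limit, so the full size of this step stays unknown: the limit of > 100000 nM in this assay, at which 1 of the 4 values shown sits.

From the compounds shown here alone, whether the mirror image of compound 1, which has hydrogen in place of chloro, would show the same preference remains open. So does whether it would hold with an amine in place of chloro, or with a carboxylic acid in place of the ethyl ester.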